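Three inactive chalcone analogues and a planned dimethoxy variant

The source may hold more compounds than are shown below. What is called first, only, known or untested is meant among the compounds shown, and "the series" means these compounds.

Compound 1 `COc1ccc(/C=C/C(=O)/C=C/c2cc3ccccc3nc2Oc2ccccc2)cc1` in a functional assay on 4T1 cells (Mus musculus) for cytotoxicity, read by MTT assay, with a stated time of 48 h (a higher number here means a weaker inhibitor, a lower number a stronger inhibitor), gives > 10000 nM, which is a limit of the assay and not a number.
Compound 2 `COc1ccc(/C=C/C(=O)/C=C/c2cc3ccccc3nc2Oc2ccccc2)cc1OC` in this assay gives > 10000 nM, again a limit rather than a number.
Compound 3 `COc1ccc(/C=C/C(=O)/C=C/c2cc3ccccc3nc2Oc2ccc(Br)cc2)cc1` in this assay gives > 10000 nM, also a limit rather than a number.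

All three measured values therefore sit at the same boundary, as noted in the limit of > 10000 nM in this assay, at which 3 of the 3 values shown sit. The step from compound 1 to compound 2 is methoxy in place of hydrogen on an aromatic carbon, and its size is a step that the two limits leave unreadable from compound 1 to compound 2. The cores of compound 1 and compound 3 differ by bromo in place of hydrogen on an aromatic carbon, and that step is a step that the two limits leave unreadable from compound 1 to compound 3. Neither step can be read in size, since both ends are limits.

Compound 4 `COc1ccc(/C=C/C(=O)/C=C/c2cc3ccccc3nc2Oc2ccc(Br)cc2)c(OC)c1` has not yet been measured. It differs from compound 3 by methoxy in place of hydrogen on an aromatic carbon. This is the same kind of change as that from compound 1 to compound 2, though not the same: in compound 2 the entering methoxy sits ortho to a methoxy group and meta to a large group, whereas in compound 4 it sits ortho to a large group and meta to a methoxy group.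

For compound 4 in this assay the step that the limit leaves unreadable from compound 3 to compound 4 is expected, on the grounds that compound 3 gives only a limit in > 10000 nM and that the related change from compound 1 to compound 2 left both ends at the limit in a step that the two limits leave unreadable from compound 1 to compound 2. Compound 4 is estimated at 15000 nM, most likely reported once more only as a limit, with a range from 5000 nM to 50000 nM.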

Compound 4, half-maximal inhibitory concentration: > 10000 nM
Compound 4 was reported as a limit (the forecaster's own chance of this, stated with the estimate: 80%); the middle value does not contradict the limit.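

Among the compounds shown here, compound 4, like compound 3, is reported only as a limit, so the step between them cannot be read, and no new step can be drawn from this result. All the values shown stand at a single boundary: the limit of > 10000 nM in this assay, at which 4 of the 4 values shown sit. What the compounds shown leave open is how far each lies beyond that limit in this assay and whether methoxy or bromo in place of hydrogen changes the result at all.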